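The compounds below may be only part of what the source reports. "The series", "measured", "known", "first", "only" and "open" are said of these compounds alone.

Working notes on the series.

The set comprises three measured compounds and one open position. Compound 1 `Cc1nc(N2CCC2)nc(OC2CCC2)c1O` carries a methyl group; in a functional assay on cells (Lymphocyte, Homo sapiens), read by a luciferase reporter and ATP content, with a stated time of 48 h, tested at 20 uM (a higher number here means a weaker effect of the compound at the concentration tested, a lower number a stronger effect), compound 1 gives 96%. Compound 3 `Cc1nc(OC2CCC2)nc(OC2CCC2)c1O` differs from it by one change, (cyclobutyloxy in place of azetidin-1-yl on an aromatic carbon), and in this assay compound 3 gives 97%. The step of a number 1 percentage points higher from compound 1 to compound 3 (within the scatter) is therefore flat. Compound 2 `CCCCCCCCCCCCCCc1nc(OC2CCC2)nc(N2CCC2)c1O` carries the long chain in place of the methyl group and is arranged differently; the difference between the core of compound 2 and the core of compound 1 is not broken down here. In this assay compound 2 gives 54%, the lowest of the three numbers, beyond the scatter from both compound 1 and compound 3.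

Compound 4 `CCCCCCCCCCCCCCc1nc(OC2CCC2)nc(OC2CCC2)c1O` is not yet measured. Its change from compound 2, (cyclobutyloxy in place of azetidin-1-yl on an aromatic carbon), is the same kind of change as that from compound 1 to compound 3, but the surroundings differ: in compound 1 the exchanged group sits between two ring nitrogen atoms and para to a hydroxy group, whereas in compound 2 it sits next to the ring nitrogen, ortho to a hydroxy group and meta to a large group. Going by the values given here, with only one precedent, the expectation is that the step from compound 2 to compound 4 is again small, because the step of a number 1 percentage points higher from compound 1 to compound 3 (within the scatter) was within the scatter; the expected step is a number 4 percentage points higher from compound 2 to compound 4 (within the scatter). The surroundings being different, a wider range is allowed. Compound 4 is estimated at 58%, with a range from 38% to 82%.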

Compound 4, a percentage reported as activity, at one concentration (the size of the read-out at that concentration, not a potency): 94%
Estimate against measurement, compound 4: 36 percentage points below; measured number above the stated range.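

In this assay, the exchange of azetidin-1-yl for cyclobutyloxy does not carry over from one core to the other with a single size: the same change on two cores in this assay, a number 1 percentage points higher (within the scatter) from compound 1 to compound 3 and a number 40 percentage points higher (beyond the scatter) from compound 2 to compound 4, 39 percentage points apart, beyond the scatter of two such steps

On the core with the long chain, the change gives a number 40 percentage points higher from compound 2 to compound 4 (beyond the scatter), so the lower number on that core goes with azetidin-1-yl, and the flat step on the core with the methyl group was no guide to it. These two pairs do not show why the step differs, since the cores differ both in the long chain and in the place of the exchanged group, and the two cannot be separated here; the numbers also come from a single concentration and are not potencies.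

The compounds shown leave open whether the lower number belongs to azetidin-1-yl alone or would also appear with another amine at the same place, such as pyrrolidin-1-yl or dimethylamino. They also leave open how much of the long chain is needed, which a shorter alkyl chain on the same core would address, and whether a carboxylic acid at the chain end would keep the step.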